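Ethoxy for amino on the aryl of a thiazole amine

A few compounds are considered here, and "the series" means these few. Any claim that something is new, unique, unknown or untested is made for them only; others in the source may bear on it.

Measured so far:
- compound 1 `Oc1ccc(Nc2nc(-c3ccc(F)cc3)cs2)cc1`: 60 nM
- compound 2 `Nc1ccc(-c2csc(Nc3ccc(O)cc3)n2)cc1`: 400 nM

In an assay on isolated protein for inhibition of Polyunsaturated fatty acid 5-lipoxygenase (Homo sapiens), read by HPLC, with stated times of 15 min and 10 min (on this read-out higher numbers stand for weaker inhibition and lower numbers for stronger inhibition), compound 1 gives 60 nM and compound 2 gives 400 nM. Within the data shown here, compound 2 therefore stands at the higher, weaker end of the two numbers known so far, with compound 1 as its only neighbour; the step of a 6.7-fold higher number from compound 1 to compound 2 (0.82 log units; beyond the scatter) separates them, and it lies beyond the scatter.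

Compound 3 `CCOc1ccc(-c2csc(Nc3ccc(O)cc3)n2)cc1` is not yet measured in this assay. It differs from compound 2 by ethoxy in place of amino on an aromatic carbon. Among the measured compounds shown here, only one measured step bears on this position, the step from compound 1 to compound 2, and that step shows the amino group giving the weaker number. For the measured compounds named here, no measured pair shows an ethoxy group at this place, so the direction of the new change can only be inferred loosely. Since removing the amino group undoes the change that gave compound 2 its weaker number a 6.7-fold higher number from compound 1 to compound 2 (0.82 log units; beyond the scatter), compound 3 is expected to return part of the way toward compound 1, a step of a 2.7-fold lower number from compound 2 to compound 3 (0.43 log units; beyond the scatter). Compound 3 is estimated at 150 nM, within a range from 40 nM to 600 nM.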

Compound 3, half-maximal inhibitory concentration: 30 nM
The estimate for compound 3 lay 5.0-fold (0.70 log units) above the measured number; the measured number lies below the stated range.
By their numbers in this assay, from the lowest: compounds 3 and 1 (each within the scatter of the next); then compound 2.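

In this assay, ethoxy in place of amino on this aromatic carbon gives a 13-fold lower number from compound 2 to compound 3 (1.12 log units; beyond the scatter), a large step and larger than the one that separated the first two compounds, so the position tolerates the bigger ethoxy group in this series. Ethoxy in place of fluoro gives a 2.0-fold lower number from compound 1 to compound 3 (0.30 log units; within the scatter), which lies within the scatter, so compound 1 and compound 3 cannot be told apart on this read-out. Among the three groups shown at this place, only the amino group of compound 2 stands apart, with a weaker number.

From the compounds shown here alone, whether a longer chain such as butoxy, a smaller methoxy group, or a carboxylic acid at this place would keep the number of compound 3 remains open. No measurement offered here explains why amino differs from the other two groups.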